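The compounds below may be only part of what the source reports. "The series", "measured", "known", "first", "only" and "open" are said of these compounds alone.

Measured so far in an ADME assay on HEL cells (Homo sapiens) for cytotoxicity, read by microscopy, with a stated time of 3 days; a higher number here means that more compound is tolerated, a lower number that less compound is tolerated:

Compound 1, `CCOC(=O)C1(Cc2ccccc2)CN(c2ccccc2)Cc2nnn(Cc3ccc(Cl)cc3)c21`: compound 1 gives > 100000 nM, a limit of the assay rather than a number.
Compound 2, `CCOC(=O)C1(Cc2ccccc2)CN(c2ccccc2)Cc2nnn(Cc3ccc(Cl)c(Cl)c3)c21`: compound 2 gives > 100000 nM, likewise a limit of the assay.

Compound 2 therefore stands at the upper edge of what this assay can report, with no number attached to it. For the measured compounds named here, the one further value shown, that of compound 1, is the same limit, so (the limit of > 100000 nM in this assay, at which 2 of the 2 values shown sit), and the step that the two limits leave unreadable from compound 1 to compound 2 cannot be read from these two values.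

Compound 3, `CCOC(=O)C1(Cc2ccccc2)CN(c2ccccc2)Cc2nnn(Cc3ccco3)c21`, is the next compound and differs from compound 2 by furan-2-yl in place of 3,4-dichlorophenyl on a saturated chain carbon bound to an aromatic nitrogen. Going by the values given here, the only measured step, chloro in place of hydrogen on an aromatic carbon within the 3,4-dichlorobenzyl group, is itself unreadable, so no measured step gives the size or direction of the change to (furan-2-yl)methyl in this assay.

With both values shown sitting at the limit, compound 3 is expected to remain at the limit as well, and a number no higher from compound 2 to compound 3 (the limit leaves the size open) is the expected step, meaning no change beyond the scatter. The estimate for compound 3 in this assay is 100000 nM, with a range from 30000 nM to 300000 nM.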

Compound 3, minimum cytotoxic concentration: 100000 nM
The estimate for compound 3 equals the measured number at the digits printed; measured number inside the range.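

In this assay, for the compounds shown here, compound 3 gives 100000 nM, the first value that is a number and not a limit of the assay. With furan-2-yl in place of 3,4-dichlorophenyl on a saturated chain carbon bound to an aromatic nitrogen, the change reads as a number no higher from compound 2 to compound 3 (the limit leaves the size open), and with furan-2-yl in place of 4-chlorophenyl at the same place it reads as a number no higher from compound 1 to compound 3 (the limit leaves the size open); neither size can be read, so neither step can be placed within or beyond the usual scatter. This position therefore takes a five-membered aromatic ring with 1 hetero atom as well as the chlorinated phenyl rings, and the number for compound 3 lands at the value where the limits of the other two compounds stand: the limit of > 100000 nM in this assay, at which 2 of the 3 values shown sit.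

From the compounds shown here alone, whether compound 3 truly differs from compound 1 and compound 2 stays open, since neither of those two has a number to compare. Going by these compounds alone, equally open is whether a basic amine or a carboxylic acid on this saturated chain carbon would give a number clearly apart from the one for compound 3.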